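A Triazole Aryl Swap on a Weakly Active Core

The source may report more compounds than this note shows. Statements on the series, on what has been measured and on what is new or still open speak of the compounds shown alone.

Measured compounds:
compound 1 `N#CC1=C(N)Oc2c(c3nc4ccccc4nc3c3ccccc23)C12C(=O)N(Cc1cnnn1-c1ccc(Br)cc1)c1ccccc12` — 36600 nM
compound 2 `N#CC1=C(N)Oc2c(c3nc4ccccc4nc3c3ccccc23)C12C(=O)N(Cc1cnnn1-c1cccc(S(N)(=O)=O)c1)c1ccccc12` — 42500 nM
compound 3 `CCOc1ccccc1-n1nncc1CN1C(=O)C2(C(C#N)=C(N)Oc3c(N)cc4nc5ccccc5nc4c32)c2ccccc21` — > 50000 nM

The three measured compounds were tested in a functional assay on MCF7 cells (Homo sapiens) for antiproliferative activity, read by MTT assay, with a stated time of 48 h; on this read-out lower numbers stand for stronger inhibition and higher numbers for weaker inhibition. Compound 1 gives 36600 nM and compound 2 gives 42500 nM, and the step of a 1.2-fold higher number from compound 1 to compound 2 (0.06 log units; within the scatter), which swaps the aryl group on the aromatic nitrogen, changes nothing beyond the scatter. For compound 3 the assay returns only a limit, > 50000 nM. Compound 3 thus sits at the limit of > 50000 nM in this assay, at which 1 of the 3 values shown sits, the weakest reading of the set, with no exact number known for it.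

Compound 4 `N#CC1=C(N)Oc2c(N)cc3nc4ccccc4nc3c2C12C(=O)N(Cc1cnnn1-c1ccc(F)c(Cl)c1)c1ccccc12` differs from compound 3 in one place: 3-chloro-4-fluorophenyl in place of 2-ethoxyphenyl on an aromatic nitrogen. Among the measured compounds shown here, the only measured step that bears on this kind of change is a 1.2-fold higher number from compound 1 to compound 2 (0.06 log units; within the scatter), an aryl swap at the same aromatic nitrogen that stayed within the scatter. On that basis the step of a number no higher from compound 3 to compound 4 (the limit leaves the size open) is expected to be none beyond the scatter, leaving compound 4 near the limit. Compound 4 is therefore estimated at about 50000 nM, within a range from 25000 nM to 100000 nM, with a fair chance that this assay again reports only a limit.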

Compound 4, half-maximal inhibitory concentration: 17800 nM
For compound 4 the middle estimate is 2.8-fold (0.45 log units) above the measured one; the measured number lies below the stated range.
By their numbers in this assay, from the lowest: compound 4; then compounds 1 and 2 (each within the scatter of the next). At a limit, above all of these: compound 3.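

In this assay, an at least 2.8-fold lower number from compound 3 to compound 4 (0.44 log units; beyond the scatter), so an aryl swap on this aromatic nitrogen can move the read-out beyond the scatter, which the earlier swap, a 1.2-fold higher number from compound 1 to compound 2 (0.06 log units; within the scatter), did not show. From the compounds shown here alone, the true size of the new step stays open, since compound 3 gives a limit and not a number: the limit of > 50000 nM in this assay, at which 1 of the 4 values shown sits. The change removes 2-ethoxyphenyl and brings in 3-chloro-4-fluorophenyl at the same place, so the gain is tied to this exchange as a whole and not to any one atom of it.

The compounds shown leave open whether the chlorine, the fluorine or the loss of the ethoxy group carries the step. They also leave open whether an amine or a carboxylic acid on this phenyl ring would give a step of the same kind.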